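This account rests on a few compounds, and the source may have more. Where it says the series, first, only, none or still open, it means among the compounds named here.

Measured in a functional assay on SW-620 cells (Homo sapiens); on this read-out lower numbers stand for stronger inhibition of growth and higher numbers for weaker inhibition of growth:
- compound 1 `O=S(=O)(/C=C/c1ccc(Cl)c(Cl)c1)Cc1ccc(Nc2ncnc3ccc(Br)cc23)cc1` gives 5000 nM
- compound 2 `O=S(=O)(/C=C/c1ccc(Cl)cc1)Cc1ccc(Nc2ncnc3ccc(Br)cc23)cc1` gives 45000 nM
- compound 3 `O=S(=O)(/C=C/c1ccc(C(F)(F)F)cc1F)Cc1ccc(Nc2ncnc3ccc(Br)cc23)cc1` gives 55000 nM

Compound 3 stands at the weak end of this small set, with a 1.2-fold higher number from compound 2 to compound 3 (0.09 log units; within the scatter) and an 11-fold higher number from compound 1 to compound 3 (1.04 log units; beyond the scatter) as its two gaps. Compound 4 `O=S(=O)(/C=C/c1ccc(F)cc1F)Cc1ccc(Nc2ncnc3ccc(Br)cc23)cc1` has not yet been measured. It differs from compound 3 by fluoro in place of trifluoromethyl on an aromatic carbon. Going by the values given here, the nearest precedent is the exchange of 4-chlorophenyl for 2-fluoro-4-(trifluoromethyl)phenyl, which gave a 1.2-fold higher number from compound 2 to compound 3 (0.09 log units; within the scatter). The larger step of a 9.0-fold higher number from compound 1 to compound 2 (0.95 log units; beyond the scatter) starts from the 3,4-dichlorophenyl group, which compound 4 lacks. No step beyond the scatter is therefore expected in this assay, the estimated move being a 1.4-fold lower number from compound 3 to compound 4 (0.14 log units; within the scatter). For compound 4 the expected value is 40000 nM, with an estimated range of 15000 nM to 100000 nM.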

Compound 4, concentration for 50% growth inhibition: 100000 nM
Estimate against measurement, compound 4: 2.5-fold (0.40 log units) below; the range from low to high includes it.
By their numbers in this assay, from the lowest: compound 1; then compounds 2, 3 and 4 (each within the scatter of the next, the first and the last beyond it).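

In this assay fluoro in place of trifluoromethyl at this ring position gives a 1.8-fold higher number from compound 3 to compound 4 (0.26 log units; within the scatter) and so does not separate the two compounds. The 2,4-difluorophenyl group does separate from 4-chlorophenyl, with a 2.2-fold higher number from compound 2 to compound 4 (0.35 log units; beyond the scatter) as a modest gap, and from 3,4-dichlorophenyl, with a 20-fold higher number from compound 1 to compound 4 (1.30 log units; beyond the scatter) as a large one, leaving compound 1 alone at the low end of the numbers. No measurement at hand bears on the reason for these gaps. Still open, going by these compounds, is whether an amine or a carboxylic acid at this ring position would move the number in this assay beyond the scatter.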